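Methoxyphenyl in place of dichlorophenyl on the chain

A few compounds are considered here, and "the series" means these few. Any claim that something is new, unique, unknown or untested is made for them only; others in the source may bear on it.

Going by the values given here, the two measured members share the core of compound 1 `O=C(CCCc1ccccc1)Nc1nc2ccccc2c(=O)s1` and differ only in the aryl group at the end of the chain. Among the compounds with values here, in an in vitro assay on cells for inhibition of Amine oxidase [flavin-containing] B (Homo sapiens), read by fluorescence and Amplex Red, with stated times of 30 min and 45 min (a lower number here means a stronger inhibitor, a higher number a weaker inhibitor), compound 1 gives 34.9 nM, while compound 2 `O=C(CCCc1ccc(Cl)c(Cl)c1)Nc1nc2ccccc2c(=O)s1` gives 3440 nM, the highest of the two numbers so far; the only step, a 99-fold higher number from compound 1 to compound 2 (1.99 log units; beyond the scatter), is large.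

Compound 3 `COc1cccc(CCCC(=O)Nc2nc3ccccc3c(=O)s2)c1` has not been measured. Its change from compound 2 is 3-methoxyphenyl in place of 3,4-dichlorophenyl on a saturated chain carbon, three bonds along the chain from a carbonyl carbon. Within the data shown here, the only step that bears on the aryl group is a 99-fold higher number from compound 1 to compound 2 (1.99 log units; beyond the scatter), which shows the phenyl-to-dichlorophenyl exchange raising the number far beyond the scatter. The 3-methoxyphenyl of compound 3 is neither the phenyl of compound 1 nor the 3,4-dichlorophenyl of compound 2, so a return toward compound 1 is expected only in part; the number for compound 3 is expected to fall between those of the two measured compounds, a step of a 9.8-fold lower number from compound 2 to compound 3 (0.99 log units; beyond the scatter) downward. The estimate for compound 3 in this assay is 350 nM, within 60 nM to 2500 nM.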

Compound 3, half-maximal inhibitory concentration: 389 nM
Compound 3: middle estimate off by 1.1-fold (0.05 log units), on the low side, and the stated range covers the measured number.
By their numbers in this assay, from the lowest: compound 1; then compound 3; then compound 2.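

The aryl group at the end of the chain in this assay proves graded rather than all-or-nothing: an 8.8-fold lower number from compound 2 to compound 3 (0.95 log units; beyond the scatter) shows that the 3-methoxyphenyl recovers part of the loss seen with the 3,4-dichlorophenyl, even though both groups have the same heavy-atom count. Going by these compounds alone, at the same time, an 11-fold higher number from compound 1 to compound 3 (1.05 log units; beyond the scatter) shows that one methoxy in place of hydrogen on an aromatic carbon is enough on its own to move the number beyond the scatter, so among the three compounds both substituted aryl groups stand above the plain phenyl, with no compound going against this. Nothing at hand gives a reason for these differences.

The three compounds do not separate the kind of substituent from the number of substituents, since the dichlorophenyl carries two and the methoxyphenyl one, and a single chlorine on the phenyl would bear directly on that question. Also open, on these data alone, is how smaller groups such as fluorine or hydroxy would read at this place, and whether a shorter or longer chain would change the size of these steps.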